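This account rests on a few compounds, and the source may have more. Where it says the series, first, only, none or still open, it means among the compounds named here.

Measured so far in a functional assay on MCF7 cells (Homo sapiens) for cytotoxicity, read by MTT assay, with a stated time of 48 h; on this read-out lower numbers stand for stronger inhibition of growth and higher numbers for weaker inhibition of growth:
Compound 1 `FC(F)(F)c1cccc(Cn2c(C(F)(F)F)nc3cc(Cl)c(Cl)cc32)c1` gives 68000 nM.
Compound 2 `FC(F)(F)c1ccc(Cn2c(C(F)(F)F)nc3cc(Cl)c(Cl)cc32)cc1` gives 17000 nM.
Compound 3 `O=[N+]([O-])c1cccc(Cn2c(C(F)(F)F)nc3cc(Cl)c(Cl)cc32)c1` gives 60000 nM.

Compound 2 holds the lowest number of the three; the values of compound 3 and compound 1 lie beyond the scatter from it. The change nitro in place of trifluoromethyl on an aromatic carbon produced a 1.1-fold lower number from compound 1 to compound 3 (0.05 log units; within the scatter). The cores of compound 1 and compound 2 are built from the same atoms joined differently; the difference between the two cores is not broken down here.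

Compound 4 `O=[N+]([O-])c1ccc(Cn2c(C(F)(F)F)nc3cc(Cl)c(Cl)cc32)cc1` carries nitro in place of trifluoromethyl on an aromatic carbon. This is the same kind of change as that from compound 1 to compound 3, but the place differs: meta to a large group in the first pair, para to a large group in the second. Among the measured compounds shown here, the step expected in this assay is a 1.1-fold lower number from compound 2 to compound 4 (0.03 log units; within the scatter), resting on the small size of a 1.1-fold lower number from compound 1 to compound 3 (0.05 log units; within the scatter), the only measured example of this change. Compound 4 is therefore estimated at 16000 nM, with a range from 6000 nM to 45000 nM.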

Compound 4, concentration for 50% growth inhibition: 97300 nM
The estimate for compound 4 lay 6.1-fold (0.78 log units) below the measured number, and the stated range ends below it.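

In this assay, nitro in place of trifluoromethyl on an aromatic carbon gives a 5.7-fold higher number from compound 2 to compound 4 (0.76 log units; beyond the scatter). The step measured on one core therefore does not transfer as a fixed step to the other core: the same change on two cores in this assay, a 1.1-fold lower number (0.05 log units; within the scatter) from compound 1 to compound 3 and a 5.7-fold higher number (0.76 log units; beyond the scatter) from compound 2 to compound 4, 6.5-fold (0.81 log units) apart, beyond the scatter of two such steps. Two pairs show that the outcome of this change depends on the core, but they do not show which feature of the cores sets the size of the step, or how the change would read on any further core.

Still open, as far as these compounds go, is whether a nitrile, an amine or a carboxylic acid at the same aromatic carbon would give values nearer compound 2 or compound 4. Equally open, from the compounds shown here alone, is whether the same split between cores would appear with those groups.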